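The compounds below may be only part of what the source reports. "The series", "measured", "known", "first", "only" and "open" are said of these compounds alone.

Three related compounds have been tested so far in a functional assay on HeLa cells (Homo sapiens) for cytotoxicity, read by MTT assay; a higher number here means a weaker inhibitor, a lower number a stronger inhibitor. Compound 1 `COc1cc(O)c(CC=C(C)C)c(O)c1C(=O)/C=C/c1cc(O)c(O)c(O)c1` gives 30300 nM, and compound 2 `COc1ccc(/C=C/C(=O)c2c(OC)cc(O)c(CC=C(C)C)c2O)cc1OC` gives 17100 nM. Compound 3 `COc1cc(O)c(CC=C(C)C)c(O)c1C(=O)/C=C/c1cccc(O)c1` gives 4800 nM, the lowest number of the three, which makes it the strongest inhibitor so far.

Compound 4 `COc1cc(O)c(CC=C(C)C)c(O)c1C(=O)/C=C/c1ccc(O)c(O)c1` has not yet been measured. It differs from compound 3 by a single change, hydroxy in place of hydrogen on an aromatic carbon, turning 3-hydroxyphenyl into 3,4-dihydroxyphenyl. This group is an intermediate case, with the 3-hydroxyphenyl of compound 3 on one side and the 3,4,5-trihydroxyphenyl of compound 1 on the other.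

Among the compounds with values here, the one measured step that bears on this is a 6.3-fold lower number from compound 1 to compound 3 (0.80 log units; beyond the scatter), where 3-hydroxyphenyl replaces 3,4,5-trihydroxyphenyl. Compound 2 differs from these compounds in more than one place, so it offers no clean comparison. Adding a hydroxy should partly reverse that step, so a smaller move towards a higher number is expected, though one step is thin evidence. The expected change is a 2.5-fold higher number from compound 3 to compound 4 (0.40 log units; beyond the scatter). For compound 4 the estimated value is 12000 nM, with a range of 5500 nM to 27000 nM.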

Compound 4, half-maximal inhibitory concentration: 2500 nM
Beside the measured number, compound 4's estimate is 4.8-fold (0.68 log units) above it; the whole stated range lies above it.
By their numbers in this assay, from the lowest: compounds 4 and 3 (each within the scatter of the next); then compounds 2 and 1 (each within the scatter of the next).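

Adding a hydroxy to turn 3-hydroxyphenyl into 3,4-dihydroxyphenyl gives a difference that cannot be told apart from ordinary repeat variation (a 1.9-fold lower number from compound 3 to compound 4 (0.28 log units; within the scatter)), so this position accepts either hydrogen or hydroxy in this assay as far as the data can show. The large change lies elsewhere: going from the 3,4,5-trihydroxyphenyl of compound 1 to the 3,4-dihydroxyphenyl of compound 4 involves a single hydroxy and gives a 12-fold lower number from compound 1 to compound 4 (1.08 log units; beyond the scatter), so the loss of that one group matches or exceeds the whole effect seen earlier for the removal of two. No measurement shown here explains either step.

Still open, on these data alone, is how an amine, a fluorine or a methoxy on this same aromatic carbon would compare with hydrogen and hydroxy. Also open, as far as these compounds go, is whether the same pattern would hold with a longer chain in place of the prenyl-type side chain on the shared core.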